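The compounds below may be only part of what the source reports. "The series", "measured", "known", "first", "only" and "open" are said of these compounds alone.

Compound 1, `Fc1ccc(/C=N/c2sc3c(c2-c2nc4ccccc4s2)CCC3)cc1`: 290 ug/mL
Compound 2, `Fc1ccccc1/C=N/c1sc2c(c1-c1nc3ccccc3s1)CCCC2`: 319 ug/mL
Compound 3, `COc1cc(/C=N/c2sc3c(c2-c2nc4ccccc4s2)CCCC3)cc(OC)c1OC`: 381 ug/mL

These three compounds share one core and differ only in the aromatic ring attached through the imine. All three were measured in an ADME assay on cells (Rhabdomyosarcoma cell, Homo sapiens) for cytotoxicity, read by MTT assay, with a stated time of 72 h; on this read-out higher numbers stand for lower toxicity in this test and lower numbers for higher toxicity in this test. Compound 2 gives 319 ug/mL, the second highest of the three numbers. Its nearest neighbour is compound 1 with 290 ug/mL, and the furthest is compound 3 with 381 ug/mL; both gaps lie within the usual scatter, so on this read-out the three compounds cannot be told apart.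

The new compound is compound 4, `Oc1ccccc1/C=N/c1sc2c(c1-c1nc3ccccc3s1)CCCC2`. It arises from compound 2 by a single change: hydroxy in place of fluoro on an aromatic carbon. In words, hydroxy takes the place of fluoro on an aromatic carbon, ortho to a large group.

Among the measured compounds shown here, no pair of measured compounds differs in just one place, so there is no measured step to lean on. The three measured values sit close together despite quite different ring substituents, and the expected step is therefore a 1.0-fold higher number from compound 2 to compound 4 (0.00 log units; within the scatter), no larger than the scatter and in no set direction. Compound 4 is estimated at 320 ug/mL in this assay, with a range from 170 ug/mL to 600 ug/mL.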

Compound 4, half-maximal cytotoxic concentration: 42.4 ug/mL
Compound 4: middle estimate off by 7.5-fold (0.88 log units), on the high side; measured number below the stated range.
By their numbers in this assay, from the lowest: compound 4; then compounds 1, 2 and 3 (each within the scatter of the next).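

In this assay the swap of fluoro for hydroxy on an aromatic carbon, ortho to a large group, gives a 7.5-fold lower number from compound 2 to compound 4 (0.88 log units; beyond the scatter) and so moves the compound toward higher toxicity in this test by more than the usual scatter. The earlier compounds shown here offered no pair differing in just one place, and their close values gave no sign that a single change on this ring could shift the read-out so clearly; this pair shows that the position can matter, at least for this change. Nothing available explains why the number falls with this swap.

Going by these compounds, whether the shift depends on hydroxy in particular remains open, as an amine or a carboxylic acid at the same place could lower the number just as far, or leave it unchanged. On these data alone, it is also open whether the same swap would have a similar effect on the core of compound 1, or at another place on the ring, so this single step should not yet be treated as a general rule.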